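Methyl on the Ring Nitrogen: Will the Step Repeat?

The compounds below may be only part of what the source reports. "The series", "measured", "known", "first", "only" and "open" are said of these compounds alone.

Compound 1 `COc1cc(/C=C/c2c[nH]c3ccccc23)cc(OC)c1OC` carries a hydrogen on the aromatic nitrogen of its core. In a functional assay on A549 cells (Homo sapiens) for inhibition (a higher number here means a weaker inhibitor, a lower number a stronger inhibitor), compound 1 gives 3230 nM. Compound 2 `COc1cc(/C=C/c2cn(C)c3ccccc23)cc(OC)c1OC` differs from compound 1 by methyl in place of hydrogen on an aromatic nitrogen, and in this assay compound 2 gives 3090 nM, so that a 1.0-fold lower number from compound 1 to compound 2 (0.02 log units; within the scatter).

Compound 3 `COc1cc(/C=C/c2ccc3[nH]ccc3c2)cc(OC)c1OC` is built from the same atoms as compound 1, joined differently; the difference between the two cores is not broken down here. In this assay compound 3 gives 470 nM, the lowest of the three numbers, and its distance from compound 1 and from compound 2 lies beyond the scatter.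

Compound 4 `COc1cc(/C=C/c2ccc3c(ccn3C)c2)cc(OC)c1OC` has not been measured. It differs from compound 3 by methyl in place of hydrogen on an aromatic nitrogen. This is the same kind of change as that from compound 1 to compound 2, though the surroundings differ: in compound 1 the aromatic nitrogen sits two ring bonds from the ring atom that bears a large group, which is not stated for compound 3. Because a 1.0-fold lower number from compound 1 to compound 2 (0.02 log units; within the scatter), this kind of change is expected to move the number little here as well, no change at the digits printed from compound 3 to compound 4 (within the scatter). In this assay compound 4 is expected to give 470 nM. The estimate for compound 4 is expected to lie between 200 nM and 1100 nM.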

Compound 4, half-maximal inhibitory concentration: 470 nM
The estimate for compound 4 equals the measured number at the digits printed; low and high end bracket the measured number.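

The new pair shows no change at the digits printed from compound 3 to compound 4 (within the scatter) in this assay, and the same change reads alike on the two cores: the same change on two cores in this assay, a 1.0-fold lower number (0.02 log units; within the scatter) from compound 1 to compound 2 and no change at the digits printed (within the scatter) from compound 3 to compound 4, 1.0-fold (0.02 log units) apart, within the scatter of two such steps. Across these two pairs, then, methyl can stand in place of hydrogen on the aromatic nitrogen with no visible effect on the number, on the core of compound 1 as well as on the core of compound 3, although those two cores give clearly different numbers. Among these compounds, this rests on only two pairs in a single assay, so it does not show that the step would carry to any further core, and it does not explain why the cores differ.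

The compounds shown leave open whether a larger group on that same nitrogen, such as an ethyl group, a longer chain or a chain ending in an amine, would also leave the number in place. They also leave open whether an acetyl group there, with its carbonyl, would behave as methyl does.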